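A few compounds are considered here, and "the series" means these few. Any claim that something is new, unique, unknown or untested is made for them only; others in the source may bear on it.

Measured compounds, with the number each gives in a functional assay on isolated protein for inhibition of Glucose-dependent insulinotropic receptor (Rattus norvegicus), read by HTRF and cAMP accumulation; a lower number here means that less compound is needed, a higher number that more compound is needed for the effect:
compound 1 `Cc1nc(S(C)(=O)=O)ccc1Oc1ncnc(OC2CCN(C(=O)O[C@H](C)CF)CC2)c1F` — compound 1 gives 1520 nM
compound 2 `Cc1nc(S(C)(=O)=O)ccc1Oc1ncnc(OC2CCN(C(=O)O[C@H](C)C(F)(F)F)CC2)c1F` — compound 2 gives 110 nM
compound 3 `Cc1nc(S(C)(=O)=O)ccc1Oc1ncnc(OC2CCN(C(=O)OC3(C(F)(F)F)CCC3)CC2)c1F` — compound 3 gives 63.3 nM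

Compound 2 stands second highest of the three numbers: its nearest neighbour is compound 3, with a 1.7-fold lower number from compound 2 to compound 3 (0.24 log units; within the scatter), and its furthest is compound 1, with a 14-fold lower number from compound 1 to compound 2 (1.14 log units; beyond the scatter). For the measured compounds named here, the one large measured step among the three, a 24-fold lower number from compound 1 to compound 3 (1.38 log units; beyond the scatter), like the others concerns only the group on the oxygen next to the carbonyl group.

Compound 4 `Cc1nc(S(C)(=O)=O)ccc1Oc1ncnc(OC2CCN(C(=O)SC3CC3)CC2)c1F` is not yet measured. It differs from compound 2 as follows: a group of 4 heavy atoms (3 carbon, 1 sulfur; one three-membered non-aromatic ring of carbon only) in place of a group of 7 heavy atoms (3 carbon, 1 oxygen, 3 fluorine; no ring), on a carbonyl carbon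

Going by the values given here, no measured step bears directly on this change. Every step shown keeps an oxygen on the carbonyl carbon and alters only the carbon chain or ring carried on that oxygen; here the oxygen itself and all three fluorines leave, and a sulfur with a three-membered non-aromatic ring of carbon only enters. What the measured steps do show is that, within this series, removing fluorines from the group on the carbonyl carbon is linked with a large rise in the number, as in the reverse of a 14-fold lower number from compound 1 to compound 2 (1.14 log units; beyond the scatter). By that analogy, and with wide uncertainty, a rise for compound 4 is expected, of about a 3.6-fold higher number from compound 2 to compound 4 (0.56 log units; beyond the scatter). Compound 4 is therefore estimated at 400 nM, with a range from 90 nM to 2500 nM.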

Compound 4, half-maximal effective concentration: 126 nM
Estimate against measurement, compound 4: 3.2-fold (0.50 log units) above; measured number inside the range.
By their numbers in this assay, from the lowest: compounds 3, 2 and 4 (each within the scatter of the next); then compound 1.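

In this assay, the carbonyl carbon whose other neighbour is the amide-type nitrogen in a ring accepts a group with sulfur in place of oxygen, a three-membered ring and no fluorine, and the number stays level with both fluorinated comparators (a 1.1-fold higher number from compound 2 to compound 4 (0.06 log units; within the scatter); a 2.0-fold higher number from compound 3 to compound 4 (0.30 log units; within the scatter)). The link between fluorine and a lower number therefore does not hold across the series: it fits compounds 1, 2 and 3, whereas compound 4 goes against it, carrying no fluorine yet sitting well clear of the monofluorinated compound 1 (a 12-fold lower number from compound 1 to compound 4 (1.08 log units; beyond the scatter)). Nothing available here accounts for this result.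

Compound 4 changes the linking atom and the carbon group together, so the contribution of sulfur cannot be separated from that of the three-membered ring, and an oxygen-linked three-membered ring or a sulfur-linked 1-(trifluoromethyl)ethyl group would be needed to divide them. Also open, from the compounds shown here alone, is how an amine nitrogen carrying the same three-membered ring would behave on this carbonyl carbon.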